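Butyl Added to the Aromatic Ring of Compound 2

The source may hold more compounds than are shown below. What is called first, only, known or untested is meant among the compounds shown, and "the series" means these compounds.

Compound 1: `CCOC(=O)/C=C1/C(=O)Nc2ccccc21` gives 86.9%
Compound 2: `CC(C)(C)OC(=O)/C=C1/C(=O)Nc2ccccc21` gives 87.6%

In a functional assay on MDA-MB-231 cells (Homo sapiens) for inhibition, read by CCK-8 assay, with a stated time of 72 h, tested at 20 uM (on this read-out higher numbers stand for more inhibition of growth at the one concentration tested and lower numbers for less inhibition of growth), compound 1 gives 86.9% and compound 2 gives 87.6%. Among the measured compounds shown here, the only measured step, a number 0.7 percentage points higher from compound 1 to compound 2 (within the scatter), changes nothing beyond the scatter. Compound 2 holds the higher of the two numbers, though compound 1 sits within the scatter of it, so the two cannot be ranked.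

Compound 3 is `CCCCc1ccc2c(c1)/C(=C\C(=O)OC(C)(C)C)C(=O)N2`. It differs from compound 2 in this way: butyl in place of hydrogen on an aromatic carbon. For the measured compounds named here, no measured step touches the aromatic carbon; the single measured step, a number 0.7 percentage points higher from compound 1 to compound 2 (within the scatter), concerns tert-butyl in place of ethyl and lies within the scatter, so it offers no guide to a butyl group on the ring. Compound 3 is therefore expected to stay near compound 2, with an expected step of a number 3.6 percentage points lower from compound 2 to compound 3 (within the scatter) in this assay. The estimate for compound 3 is 84%, within 65% to 95%.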

Compound 3, percent growth inhibition at one concentration: 87.7%
Compound 3: the middle estimate sits 3.7 percentage points below what was measured; measured number inside the range.
By their numbers in this assay, from the lowest: compounds 1, 2 and 3 (each within the scatter of the next).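

In this assay, placing butyl on this aromatic carbon, the one meta to a fused ring and para to a fused ring, gives a number 0.1 percentage points higher from compound 2 to compound 3 (within the scatter). Among the compounds shown here, this is the first measured change on the ring of the shared core, and it shows that this position can carry a butyl chain, with no ring and no net charge, without a number that can be told apart from that of compound 2. The data available offer no explanation for this result.

Left open is whether an amine, a carboxylic acid or a longer chain on the same aromatic carbon would also leave the number within the scatter of compound 2. Also open, on these data alone, is whether butyl at this position would give the same outcome with ethyl in place of tert-butyl on the ester oxygen.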